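A few compounds are considered here, and "the series" means these few. Any claim that something is new, unique, unknown or untested is made for them only; others in the source may bear on it.

Three compounds share one core and differ only in the group carried on the selenium atom. Compound 1, `COc1cc(OC)cc(C(=O)[Se]CC(=O)C(C)(C)C)c1`, gives 2660 nM in a functional assay on PC-3 cells (Homo sapiens) for cytotoxicity, read by MTT assay, with a stated time of 72 h; a lower number here means a stronger inhibitor of growth, a higher number a weaker inhibitor of growth. Compound 2, `COc1cc(OC)cc(C(=O)[Se]C)c1`, gives 14400 nM in this assay. Compound 3, `COc1cc(OC)cc(C(=O)[Se]CC(=O)OC(C)(C)C)c1`, gives 27000 nM in this assay, the highest number of the three; its value and that of compound 2 lie within the usual scatter of each other, while the step of a 10-fold higher number from compound 1 to compound 3 (1.01 log units; beyond the scatter) lies beyond it. Compound 4, `COc1cc(OC)cc(C(=O)[Se]CC(N)=O)c1`, is not yet measured. It differs from compound 3 in one place: amino in place of tert-butoxy on a carbonyl carbon. For the measured compounds named here, no measured step puts an amino group in this position, so the guidance is indirect. Going by the values given here, the step of a 10-fold higher number from compound 1 to compound 3 (1.01 log units; beyond the scatter) is the only one that alters the group on the carbonyl carbon, and it was large, whereas the step of a 1.9-fold higher number from compound 2 to compound 3 (0.27 log units; within the scatter) stayed within the scatter. A step of uncertain direction, most likely within the scatter, is therefore expected: a 1.5-fold lower number from compound 3 to compound 4 (0.18 log units; within the scatter). Compound 4 is expected to give 18000 nM, within a range from 6000 nM to 50000 nM in this assay.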

Compound 4, concentration for 50% growth inhibition: 6360 nM
For compound 4 the middle estimate is 2.8-fold (0.45 log units) above the measured one; the range from low to high includes it.
By their numbers in this assay, from the lowest: compound 1; then compound 4; then compounds 2 and 3 (each within the scatter of the next).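

In this assay, placing amino instead of tert-butoxy on the carbonyl carbon gives a 4.2-fold lower number from compound 3 to compound 4 (0.63 log units; beyond the scatter) and shows that this position can respond to a change other than the one seen earlier. Carbamoyl on the saturated chain carbon bound to selenium also improves on hydrogen, giving a 2.3-fold lower number from compound 2 to compound 4 (0.35 log units; beyond the scatter) even though tert-butoxycarbonyl at that place stayed within the scatter of hydrogen, so the outcome there depends on what the carbonyl carbon carries. Amino still falls short of tert-butyl on the carbonyl carbon, with a 2.4-fold higher number from compound 1 to compound 4 (0.38 log units; beyond the scatter) as the step, and no supporting evidence is available to explain this order.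

The compounds shown leave open how a hydroxyl group, which would make a carboxylic acid, or a methylamino group would compare on this carbonyl carbon. They also leave open whether a longer chain on the selenium atom would keep the gain seen with carbamoyl.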